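Extending the alkyl chain by one carbon

A few compounds are considered here, and "the series" means these few. Any claim that something is new, unique, unknown or untested is made for them only; others in the source may bear on it.

The series shares one core, carried by compound 2 `CCCc1cc2ccccc2nc1-c1cc(-c2ccc(C(F)(F)F)cc2)no1` and compound 3 `CCCCc1cc2ccccc2nc1-c1cc(-c2ccc(C(F)(F)F)cc2)no1`, which differ only in the length of the saturated chain. In a functional assay on PC-3 cells (Homo sapiens) for inhibition, read by MTT assay, with a stated time of 24 h (on this read-out lower numbers stand for stronger inhibition and higher numbers for weaker inhibition), compound 2 gives 33800 nM, and compound 3 gives 10800 nM. Among the measured compounds shown here, the step of a 3.1-fold lower number from compound 2 to compound 3 (0.50 log units; beyond the scatter) is the only measured step in the set. Compound 3 therefore stands at the lowest of the two numbers, with compound 2 the nearest. For the measured compounds named here, compound 1 `CCCCCc1cc2ccccc2nc1-c1cc(-c2ccccc2)no1` carries a phenyl in place of the trifluoromethyl-substituted ring and a longer chain; in this assay compound 1 reaches only > 100000 nM, which is a limit of the assay and not a number, so it offers no step toward the others.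

Compound 4 `CCCCCc1cc2ccccc2nc1-c1cc(-c2ccc(C(F)(F)F)cc2)no1` is compound 3 with methyl in place of hydrogen on a saturated chain carbon, four bonds along the chain from an aromatic carbon. Going by the values given here, the one measured step that bears on this change, from compound 2 to compound 3, lengthened the same chain by one carbon and lowered the number modestly but beyond the scatter. A further extension is expected to move in the same direction, though not necessarily as far, so compound 4 is estimated at 5000 nM, within 2000 nM to 15000 nM, an expected step of a 2.2-fold lower number from compound 3 to compound 4 (0.33 log units; beyond the scatter).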

Compound 4, half-maximal inhibitory concentration: 30200 nM
Beside the measured number, compound 4's estimate is 6.0-fold (0.78 log units) below it; the measured number lies above the stated range.
By their numbers in this assay, from the lowest: compound 3; then compounds 4 and 2 (each within the scatter of the next). At a limit, above all of these: compound 1.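

In this assay this position behaves differently from the one before it: the same kind of change, methyl in place of hydrogen on a saturated chain carbon, gave a 3.1-fold lower number from compound 2 to compound 3 (0.50 log units; beyond the scatter) one carbon earlier, but four bonds along the chain from an aromatic carbon it gives a 2.8-fold higher number from compound 3 to compound 4 (0.45 log units; beyond the scatter) and so reverses the direction. With a 1.1-fold lower number from compound 2 to compound 4 (0.05 log units; within the scatter) the shortest and longest chains carrying the trifluoromethyl group cannot be told apart, and compound 3 alone stands lower than both, so among these three compounds the number does not follow chain length in one direction. Trifluoromethyl in place of hydrogen on an aromatic carbon still counts at this chain length, with an at least 3.3-fold lower number from compound 1 to compound 4 (0.51 log units; beyond the scatter), although that step starts from a limit of the assay and not from a number: the limit of > 100000 nM in this assay, at which 1 of the 4 values shown sits.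

The compounds shown leave open whether a still longer chain would raise the number further or leave it where it is. They also leave open whether the turn after compound 3 would persist with an amine or a carboxylic acid at the end of the chain.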